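Removing an Amide Methyl from an Inactive Series

The source may hold more compounds than are shown below. What is called first, only, known or untested is meant among the compounds shown, and "the series" means these compounds.

Compound 3 `CN(CC(=O)N1CCc2ccccc2C1)C(=O)c1ccc(S(C)(=O)=O)c([N+](=O)[O-])c1` is one of three close relatives tested in an assay on isolated protein for inhibition of vitamin D3 receptor (Homo sapiens), read by fluorescence polarization; on this read-out lower numbers stand for stronger inhibition and higher numbers for weaker inhibition. In this assay compound 3 gives > 60000 nM, which is a limit of the assay and not a number. Compound 1 `CN(Cc1cccc(F)c1)C(=O)CN(C)C(=O)c1ccc(S(C)(=O)=O)c([N+](=O)[O-])c1` shares the core of compound 3. In this assay compound 1 gives > 60000 nM, again a limit. Compound 2 `CC1CCN(C(=O)CN(C)C(=O)c2ccc(S(C)(=O)=O)c([N+](=O)[O-])c2)CC1` carries a different amine on the same carbonyl carbon. In this assay compound 2 gives > 60000 nM, also a limit. The steps among the three are a step that the two limits leave unreadable from compound 1 to compound 2, a step that the two limits leave unreadable from compound 1 to compound 3 and a step that the two limits leave unreadable from compound 2 to compound 3; all three values sit at the limit of > 60000 nM in this assay, at which 3 of the 3 values shown sit. Compound 4 `CS(=O)(=O)c1ccc(C(=O)NCC(=O)N2CCc3ccccc3C2)cc1[N+](=O)[O-]` differs from compound 3 by hydrogen in place of methyl on an amide-type nitrogen. For the measured compounds named here, none of the measured steps touches this nitrogen, and none has a readable size, so they offer no direction for the change. The step expected in this assay is a step that the limit leaves unreadable from compound 3 to compound 4, that is, nothing beyond the scatter. Compound 4 is expected to give 80000 nM in this assay, with a range from 30000 nM to 300000 nM, most likely again as a limit.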

Compound 4, half-maximal inhibitory concentration: 50000 nM
Compound 4: the middle estimate sits 1.6-fold (0.20 log units) above what was measured; low and high end bracket the measured number.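

With the amide hydrogen in place of methyl, this position gives the only readable number among the compounds shown, while the others stay at a single limit: the limit of > 60000 nM in this assay, at which 3 of the 4 values shown sit.

For the compounds shown here, the change on the amide-type nitrogen comes to an at least 1.2-fold lower number from compound 3 to compound 4 (0.07 log units; that floor lies within the scatter), whereas the earlier steps among compound 1, compound 2 and compound 3 cannot be read at all. In this assay, on these data alone, the value of compound 3 is a limit and not a number, so the true size of this step remains unknown, and what can be read does not separate it from the scatter.

As far as these compounds go, it remains open whether the amide hydrogen would also give a readable number with 4-methylpiperidin-1-yl or (3-fluorobenzyl)(methyl)amino on the carbonyl carbon. From the compounds shown here alone, it is also open what an ethyl group or a longer chain on this nitrogen would give.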